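Methyl for hydrogen on an alkyl chain of a shared core

The source may hold more compounds than are shown below. What is called first, only, known or untested is meant among the compounds shown, and "the series" means these compounds.

Measured compounds:
compound 1, `CCc1cc(C(C)=O)c(O)cc1OCCCCC#N`, 92%
compound 2, `CCCc1cc(C(C)=O)c(O)cc1OCCCCC#N`, 84%
compound 3, `C=CCc1cc(C(C)=O)c(O)cc1OCCCC`, 32%

In an assay on isolated protein for inhibition of leukotriene B4 receptor 1 (Homo sapiens), tested at 10 uM (a lower number here means less inhibition, a higher number more inhibition at the concentration tested (going by the name of the read-out)), compound 1 gives 92%, and compound 2 gives 84%. Compound 2 differs from compound 1 by methyl in place of hydrogen on a saturated chain carbon, two bonds along the chain from an aromatic carbon, and the step of a number 8 percentage points lower from compound 1 to compound 2 (within the scatter). Compound 3 gives 32% in this assay, a value that stands beyond the scatter below both compound 1 and compound 2. The difference between the core of compound 3 and the core of compound 1 is not broken down here.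

Compound 4, `C=CCc1cc(C(C)=O)c(O)cc1OCCCCC`, has not yet been measured in this assay. It differs from compound 3 by methyl in place of hydrogen on a saturated chain carbon, four bonds along the chain from an oxygen on an aromatic ring. This is the same kind of change as that from compound 1 to compound 2, though the place differs: there the methyl enters two bonds along the chain from an aromatic carbon, here four bonds along the chain from an oxygen on an aromatic ring. Because the earlier step of a number 8 percentage points lower from compound 1 to compound 2 (within the scatter) stayed within the scatter, compound 4 is expected to move by only a small amount, a number 1 percentage points higher from compound 3 to compound 4 (within the scatter). Compound 4 is therefore estimated at 33%, with a range from 15% to 52%.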

Compound 4, a percentage reported as inhibition, at one concentration (the size of the read-out at that concentration, not a potency): 60%
Compound 4: middle estimate off by 27 percentage points, on the low side, and the stated range ends below it.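

In this assay, the added methyl goes with a number 28 percentage points higher from compound 3 to compound 4 (beyond the scatter), so on this core the change matters, whereas the earlier step on the core of compound 1 stayed within the scatter. A methyl for hydrogen on an alkyl chain therefore cannot be carried from one core to another in this series as a fixed shift: the same change on two cores in this assay, a number 8 percentage points lower (within the scatter) from compound 1 to compound 2 and a number 28 percentage points higher (beyond the scatter) from compound 3 to compound 4, 36 percentage points apart, beyond the scatter of two such steps

This does not show that the core alone sets the outcome, since the two steps also differ in place, one two bonds along the chain from an aromatic carbon and the other four bonds along the chain from an oxygen on an aromatic ring, and two steps give no general rule.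

The compounds shown leave open how the same change would read at one and the same place on both cores. They also leave open whether a longer chain on the core of compound 4 would raise the number further, and how a carboxylic acid in place of the nitrile of compound 1 would read.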